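Methyl added to the pyridine of compound 1

A few compounds are considered here, and "the series" means these few. Any claim that something is new, unique, unknown or untested is made for them only; others in the source may bear on it.

Three thiosemicarbazone-type compounds sharing one core have been tested in a functional assay on HeLa cells (Homo sapiens) for cytotoxicity, read by MTT assay, with a stated time of 72 h, tested at 10 uM; on this read-out lower numbers stand for less inhibition of growth and higher numbers for more inhibition of growth at the one concentration tested. Compound 1 `N/C(=N\NC(=S)N1CCCCCC1)c1ccccn1` gives 67.4% and stands second highest of the three numbers. Compound 3 `Cc1cccc(/C(N)=N/NC(=S)N2CCCCC2)n1` gives 83.5% in this assay, a number above that of compound 1 by more than the usual scatter. Compound 2 `Cc1ccnc(/C(N)=N/NC(=S)N2CCSCC2)c1` gives 39.2% in this assay, a number below that of compound 1 by more than the usual scatter; compound 2 and compound 3 differ from compound 1 both in the methyl on the pyridine and in the ring attached to the thiourea, so no single change can be read from them. Compound 4 `Cc1ccnc(/C(N)=N/NC(=S)N2CCCCCC2)c1` has not yet been measured. It differs from compound 1 in one place: methyl in place of hydrogen on an aromatic carbon. For the measured compounds named here, no pair of measured compounds shows this change alone. The step from compound 1 to compound 4 is expected to be small, somewhat downward but likely within the scatter, a number 7.4 percentage points lower from compound 1 to compound 4 (within the scatter). Compound 4 is expected to give about 60% in this assay, within the range 40% to 80%.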

Compound 4, percent growth inhibition at one concentration: 55.8%
Beside the measured number, compound 4's estimate is 4.2 percentage points above it; measured number inside the range.
By their numbers in this assay, from the lowest: compound 2; then compound 4; then compound 1; then compound 3.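

In this assay, for the compounds shown here, methyl in place of hydrogen on this aromatic carbon, opposite the ring nitrogen, gives a number 11.6 percentage points lower from compound 1 to compound 4 (beyond the scatter) and is the first reading of this change on its own. The earlier compounds shown here could not show this, as each of them also carries a different ring on the thiourea; this pair shows that a single added carbon at this place is enough to move the number by more than the usual scatter, though compound 4 still gives 55.8% of growth inhibition. No measurement at hand accounts for the drop.

On these data alone, whether a methoxy group, a chlorine atom or an amine at this place would lower the number as methyl does remains open. One pair also cannot tell whether the same step would appear with a different ring on the thiourea.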